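This account rests on a few compounds, and the source may have more. Where it says the series, first, only, none or still open, it means among the compounds named here.

Measured compounds:
Compound 1 `O=c1[nH]cc(S(=O)(=O)Nc2ccccc2-c2cn(-c3ccccc3)nn2)c(=O)[nH]1`: 6650 nM
Compound 2 `Cc1ccccc1-n1cc(-c2ccccc2NS(=O)(=O)c2c[nH]c(=O)[nH]c2=O)nn1`: 6550 nM
Compound 3 `Cc1ccccc1-n1cc(-c2cccc(NS(=O)(=O)c3c[nH]c(=O)[nH]c3=O)c2)nn1`: 6230 nM

In a functional assay on OVCAR-3 cells (Homo sapiens) for antiproliferative activity, read by MTT assay, with a stated time of 24 h (on this read-out lower numbers stand for stronger inhibition and higher numbers for weaker inhibition), compound 3 gives 6230 nM, a number that stands within the scatter of compound 1 and compound 2, so no order among the three can be read. Compound 4 `O=c1[nH]cc(S(=O)(=O)Nc2cccc(-c3cn(-c4cccc(F)c4)nn3)c2)c(=O)[nH]1` differs from compound 3 by 3-fluorophenyl in place of 2-methylphenyl on an aromatic nitrogen. Among the compounds with values here, the only measured step at this place is a 1.0-fold lower number from compound 1 to compound 2 (0.01 log units; within the scatter), a change on the same phenyl ring that left the number within the scatter. Within the data shown here, no measured step covers fluorine anywhere, and no step covers a group in the 3-position of that ring. Compound 4 is therefore expected to stay close to compound 3, at 6000 nM with a range of 3000 nM to 12000 nM. The expected step is a 1.0-fold lower number from compound 3 to compound 4 (0.02 log units; within the scatter), within the scatter.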

Compound 4, half-maximal inhibitory concentration: > 20000 nM
Compound 4 ended at the assay's limit; the forecaster's own chance of this, stated with the estimate: 5%; middle value at least 3.3-fold (0.52 log units) from the limit.
By their numbers in this assay, from the lowest: compounds 3, 2 and 1 (each within the scatter of the next). At a limit, above all of these: compound 4.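

Within the data shown here, replacing 2-methylphenyl with 3-fluorophenyl on the aromatic nitrogen gives the first change at this position that lies beyond the scatter: an at least 3.2-fold higher number from compound 3 to compound 4 (0.50 log units; beyond the scatter). Among these compounds, the only earlier step here, on a phenyl ring at the same nitrogen, stayed within the scatter: a 1.0-fold lower number from compound 1 to compound 2 (0.01 log units; within the scatter). In this assay compound 4 gives > 20000 nM, which is a limit of the assay and not a number: the limit of > 20000 nM in this assay, at which 1 of the 4 values shown sits.

Among the compounds shown here, the single step exchanges methyl for fluorine and changes the substituent's ring position together, so the share of each stays open. Also open, from the compounds shown here alone, is how a phenyl ring carrying an amine or a carboxylic acid at this nitrogen would read.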